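Swapping the Aryl Group on a Shared Kinase Scaffold

The source may report more compounds than this note shows. Statements on the series, on what has been measured and on what is new or still open speak of the compounds shown alone.

Three measured compounds share one core and differ only in the aromatic group attached to it. In an assay for binding affinity to dual specificity mitogen-activated protein kinase kinase 4 (Homo sapiens), read by KINOMEscan, tested at 100 nM (on this read-out lower numbers stand for a stronger effect and higher numbers for a weaker effect at the one concentration tested), compound 1 `CCCS(=O)(=O)Nc1ccc(F)c(C(=O)c2n[nH]c3ncc(-c4cccc(OC)c4)cc23)c1F` gives 6.3%, compound 2 `CCCS(=O)(=O)Nc1ccc(F)c(C(=O)c2n[nH]c3ncc(-c4cc(Cl)cc(Cl)c4)cc23)c1F` gives 73%, and compound 3 `CCCS(=O)(=O)Nc1ccc(F)c(C(=O)c2n[nH]c3ncc(-c4ccc(C)c(C)c4)cc23)c1F` gives 20%. Compound 3 therefore stands second highest of the three: compound 1 is its nearest neighbour, while compound 2 lies furthest away, as a number 53 percentage points lower from compound 2 to compound 3 (beyond the scatter) shows. The spread tells how much this single group matters: a number 66.7 percentage points higher from compound 1 to compound 2 (beyond the scatter), whereas a number 13.7 percentage points higher from compound 1 to compound 3 (beyond the scatter).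

Compound 4 `CCCS(=O)(=O)Nc1ccc(F)c(C(=O)c2n[nH]c3ncc(-c4ccc(-c5nnn[nH]5)cc4)cc23)c1F` has not yet been measured. It differs from compound 3 in one place: 4-(1H-tetrazol-5-yl)phenyl in place of 3,4-dimethylphenyl on an aromatic carbon. The measured steps all exchange groups built from carbon, chlorine or methoxy, and none brings in a second aromatic ring or a group carrying hydrogen-bond donors and acceptors. They demonstrate that the read-out responds strongly to what sits at this position, but they offer no direction for this particular change. For compound 4 in this assay the expected step is a number 10 percentage points higher from compound 3 to compound 4 (within the scatter), with wide uncertainty in both directions. The estimate for compound 4 is 30%, expected to fall between 5% and 80%.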

Compound 4, a percentage reported as activity, at one concentration (the size of the read-out at that concentration, not a potency): 0.15%
Compound 4: middle estimate off by 29.9 percentage points, on the high side; the whole stated range lies above it.
By their numbers in this assay, from the lowest: compounds 4 and 1 (each within the scatter of the next); then compound 3; then compound 2.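

Adding a second aromatic ring at this position does not weaken the read-out: in this assay the move to 4-(1H-tetrazol-5-yl)phenyl gives a number 19.9 percentage points lower from compound 3 to compound 4 (beyond the scatter) and, against the weakest-reading group in the set, a number 72.9 percentage points lower from compound 2 to compound 4 (beyond the scatter) in a large drop. The earlier compounds shown here carried a single aromatic ring here, so they could not show that a bigger group with more heavy atoms, including a five-membered ring rich in nitrogen, is compatible with a low number at this one concentration. The comparison with the methoxy compound gives a number 6.2 percentage points lower from compound 1 to compound 4 (within the scatter) and so places no order between them, which means that two very different groups reach the same level, and no line of data here explains why this happens.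

A plain 4-phenylphenyl group or a 4-carboxyphenyl group at the same carbon would help show whether the second ring or the tetrazole's nitrogen atoms matter more for this result. A read-out at one concentration also leaves the potency of compound 1 and compound 4 unresolved, so a full concentration series would be needed to tell these two apart.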